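The compounds below may be only part of what the source reports. "The series", "measured", "known", "first", "only" and "open" are said of these compounds alone.

Measured in a functional assay (aorta) with Rattus norvegicus as the target; on this read-out lower numbers stand for an effect already at smaller amounts and higher numbers for an effect only at larger amounts of compound:
- Compound 1 `O=C1CCCN1C1=CC(CF)(CF)Oc2ccc(C(F)(F)C(F)(F)F)cc21`: 1.51 nM
- Compound 2 `O=c1ccccn1C1=CC(CF)(CF)Oc2ccc([N+](=O)[O-])cc21`: 2.46 nM

Compound 2 stands within the usual scatter of compound 1, so these numbers do not separate the two. Compound 3 `O=c1ccccn1C1=CC(CF)(CF)Oc2ccc(C(F)(F)C(F)(F)F)cc21` has 1,1,2,2,2-pentafluoroethyl in place of nitro on an aromatic carbon of compound 2: 1,1,2,2,2-pentafluoroethyl in place of nitro on an aromatic carbon. Compound 1 also carries 1,1,2,2,2-pentafluoroethyl and gives 1.51 nM, while compound 2 gives 2.46 nM. No step beyond the scatter is therefore expected in this assay. The estimated change is a 1.2-fold lower number from compound 2 to compound 3 (0.09 log units; within the scatter). For compound 3 the expected value is 2 nM, with an estimated range of 0.7 nM to 6 nM.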

Compound 3, half-maximal effective concentration: 2.95 nM
The estimate for compound 3 lay 1.5-fold (0.17 log units) below the measured number; the range from low to high includes it.
By their numbers in this assay, from the lowest: compounds 1, 2 and 3 (each within the scatter of the next).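

In this assay, 1,1,2,2,2-pentafluoroethyl in place of nitro on the aromatic carbon gives a 1.2-fold higher number from compound 2 to compound 3 (0.08 log units; within the scatter) and so leaves no readable difference between these two groups at this position. With 1,1,2,2,2-pentafluoroethyl held constant, the six-membered aromatic ring taking the place of the five-membered non-aromatic ring on the double-bonded ring carbon gives a 2.0-fold higher number from compound 1 to compound 3 (0.29 log units; within the scatter) and also stays unresolved. Nothing measured here explains why these compounds read alike.

Still open, on these data alone, is whether a smaller group such as a nitrile, or an amine or a carboxylic acid, would read the same on that aromatic carbon.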